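The source may hold more compounds than are shown below. What is called first, only, known or untested is meant among the compounds shown, and "the series" means these compounds.

Measured so far: compound 1 `CC1=NC(C)=C(C(=O)O)C(c2cccc(Cl)c2)/C1=C(\O)OC/C=C/c1ccccc1`, 20 nM; compound 2 `CC1=NC(C)=C(C(=O)O)C(c2cccc(Cl)c2)/C1=C(\O)OC/C=C/c1ccc(C)cc1`, 6.8 nM.

Within the data shown here, in a functional assay on thoracic aorta for inhibition of Voltage-gated L-type calcium channel (Rattus norvegicus) (on this read-out lower numbers stand for stronger inhibition and higher numbers for weaker inhibition), compound 2 stands at the lowest of the two numbers; the only step in hand, a 2.9-fold lower number from compound 1 to compound 2 (0.47 log units; beyond the scatter), separates it from compound 1 and lies beyond the scatter.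

Compound 3 `CC1=NC(C)=C(C(=O)O)C(c2cccc(Cl)c2)/C1=C(\O)OC/C=C/c1ccncc1` differs from compound 2 by pyridin-4-yl in place of 4-methylphenyl on a double-bonded chain carbon bound to a double-bonded chain carbon. Among the measured compounds shown here, no measured step covers this exchange. The step of a 2.9-fold lower number from compound 1 to compound 2 (0.47 log units; beyond the scatter) concerns the methyl alone, and compound 3 lacks that methyl, so a drift back toward compound 1 is expected; the ring nitrogen of pyridin-4-yl adds unknown. Compound 3 is therefore estimated at 25 nM, range 7 nM to 90 nM, which is a 3.7-fold higher number from compound 2 to compound 3 (0.57 log units; beyond the scatter), a step expected rather than known.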

Compound 3, half-maximal inhibitory concentration: 320 nM
Estimate against measurement, compound 3: 13-fold (1.11 log units) below; measured number outside the range, above it.
By their numbers in this assay, from the lowest: compound 2; then compound 1; then compound 3.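

In this assay, the ring at the end of the 3-arylprop-2-en-1-yl chain proves far more sensitive to pyridin-4-yl than to the methyl exchange: the change gives a 47-fold higher number from compound 2 to compound 3 (1.67 log units; beyond the scatter). The loss does not merely undo the methyl gain, since the comparison without methyl still gives a 16-fold higher number from compound 1 to compound 3 (1.20 log units; beyond the scatter). No available evidence accounts for this change.

Open, on these data alone, is whether pyridin-3-yl or pyridin-2-yl at this place would give a similar rise in the number. Also open, as far as these compounds go, is whether a 4-methoxyphenyl or 4-aminophenyl ring would follow compound 2 or compound 3.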